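A few compounds are considered here, and "the series" means these few. Any claim that something is new, unique, unknown or untested is made for them only; others in the source may bear on it.

Compound 1, `CC1CCN(c2c(S(=O)(=O)c3ccccc3)cnc3cc(Cl)ccc23)CC1`, gives 93% in an assay on isolated protein for displacement of a labelled ligand from metabotropic glutamate receptor 5 (Homo sapiens), with a stated time of 60 min, tested at 1 uM; a higher number here means more inhibition at the concentration tested (going by the name of the read-out), a lower number less inhibition.
Compound 2, `CC1CCN(c2c(S(=O)(=O)c3cccc(Cl)c3)cnc3cc(Cl)ccc23)CC1`, gives 92% in this assay.
Compound 3, `CC1CCN(c2c(S(=O)(=O)c3ccc(F)cc3)cnc3cc(Cl)ccc23)CC1`, gives 91% in this assay.

Compound 3 stands within the scatter of both other compounds: a number 1 percentage points lower from compound 2 to compound 3 (within the scatter) and a number 2 percentage points lower from compound 1 to compound 3 (within the scatter). Compound 4, `CC1CCN(c2c(S(=O)(=O)c3cc(Cl)cc(Cl)c3)cnc3cc(Cl)ccc23)CC1`, differs from compound 3 in one place: 3,5-dichlorophenyl in place of 4-fluorophenyl on a sulfonyl sulfur. Going by the values given here, two measured steps bear on this change, the exchange of chloro for hydrogen on an aromatic carbon, a number 1 percentage points lower from compound 1 to compound 2 (within the scatter), and the exchange of one halophenyl on the sulfonyl sulfur for another, a number 1 percentage points lower from compound 2 to compound 3 (within the scatter). Neither reaches beyond the scatter. Compound 4 is therefore expected to show no step beyond the scatter in this assay, an expected step of a number 1 percentage points higher from compound 3 to compound 4 (within the scatter). Compound 4 is estimated at 92%, with a range from 85% to 97%.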

Compound 4, a percentage reported as inhibition, at one concentration (the size of the read-out at that concentration, not a potency): 93%
The estimate for compound 4 lay 1 percentage points below the measured number; the measured number falls inside the stated range.
By their numbers in this assay, from the lowest: compounds 3, 2, 1 and 4 (each within the scatter of the next).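

Going by these compounds alone, with 3,5-dichlorophenyl on the sulfonyl sulfur, the aromatic ring carries two chloro groups for the first time, yet all three comparisons in this assay stay within the scatter: a number 2 percentage points higher from compound 3 to compound 4 (within the scatter), a number 1 percentage points higher from compound 2 to compound 4 (within the scatter) and no change at the digits printed from compound 1 to compound 4 (within the scatter). So phenyl, its singly halogenated forms and this doubly chlorinated form cannot be told apart at this position. Nothing available explains this outcome.

Going by these compounds, whether an amine or a carboxylic acid on this ring would separate from these four compounds stays open. A reading at one concentration also leaves their potencies unresolved.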